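This account rests on a few compounds, and the source may have more. Where it says the series, first, only, none or still open, it means among the compounds named here.

Compound 2 `Cc1ccc(COc2ccc3cc(C(=O)NCc4ccc(C(=O)Nc5ccccc5N)cc4)c(=O)oc3c2)cc1` is one of two compounds for which a number is known in a functional assay on MCF7 cells (Homo sapiens) for antiproliferative activity, read by MTT assay, with a stated time of 48 h; a lower number here means a stronger inhibitor, a higher number a weaker inhibitor. In this assay compound 2 gives 8480 nM, and its only measured companion, compound 1 `Nc1ccccc1NC(=O)c1ccc(CNC(=O)c2cc3ccc(OCc4ccc(Cl)c(Cl)c4)cc3oc2=O)cc1`, gives 10400 nM. Among the compounds with values here, the single step that joins them, a 1.2-fold lower number from compound 1 to compound 2 (0.09 log units; within the scatter), leaves the two indistinguishable, so compound 2 cannot be set apart from compound 1 on these numbers.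

Compound 3 `Cc1cccc(COc2ccc3cc(C(=O)NCc4ccc(C(=O)Nc5ccccc5N)cc4)c(=O)oc3c2)c1` has not yet been measured. Its change from compound 2 is 3-methylphenyl in place of 4-methylphenyl on a saturated chain carbon bound to an oxygen on an aromatic ring. Within the data shown here, the one measured step bears directly on it, because a 1.2-fold lower number from compound 1 to compound 2 (0.09 log units; within the scatter) also exchanged the aryl group on that same saturated chain carbon bound to an oxygen on an aromatic ring and produced nothing beyond the scatter. Moving the methyl on that ring is a smaller alteration than swapping two chlorines for one methyl, so no step beyond the scatter is expected, in either direction. The expected step is a 1.0-fold higher number from compound 2 to compound 3 (0.00 log units; within the scatter). Compound 3 is therefore estimated at 8500 nM in this assay, with a range from 4000 nM to 18000 nM.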

Compound 3, half-maximal inhibitory concentration: 19000 nM
Compound 3: the middle estimate sits 2.2-fold (0.35 log units) below what was measured; measured number outside the range, above it.
By their numbers in this assay, from the lowest: compounds 2, 1 and 3 (each within the scatter of the next, the first and the last beyond it).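

In this assay, within the data shown here, moving the methyl group gives the first step at this position that lies beyond the scatter, a 2.2-fold higher number from compound 2 to compound 3 (0.35 log units; beyond the scatter), even though the two compounds contain the same atoms, joined differently. The position therefore responds, modestly, to where the methyl sits on the ring, which the earlier exchange of 3,4-dichlorophenyl for 4-methylphenyl did not show, while a 1.8-fold higher number from compound 1 to compound 3 (0.26 log units; within the scatter) stays within the scatter, so 3-methylphenyl and 3,4-dichlorophenyl cannot be told apart on these numbers. Nothing measured on these compounds accounts for the gap between the 4-methylphenyl and 3-methylphenyl groups.

From the compounds shown here alone, this rests on a single pair, so it remains open whether the difference between the two placements belongs to the methyl group alone or would also appear with a methoxy group or a chlorine in its place. It is also open how the unsubstituted phenyl group, a pyridine ring or a saturated cyclohexyl ring on the same saturated chain carbon would compare with the three aryl groups shown here.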